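Notes on the step from compound 3 to compound 4

This account rests on a few compounds, and the source may have more. Where it says the series, first, only, none or still open, it means among the compounds named here.

Measured in a functional assay on MV4-11 cells (Homo sapiens) for antiproliferative activity, read by CellTiter-Glo, with a stated time of 72 h (a lower number here means a stronger inhibitor of growth, a higher number a weaker inhibitor of growth), so far:
Compound 1 `COCCNc1cc(-c2csc(NCC3CCOCC3)n2)c(Cl)cn1` gives > 10000 nM, a limit and not a number
Compound 2 `COC[C@@H](C)N[C@H]1CC[C@H](Nc2cc(-c3csc(NCC4CCOCC4)n3)c(Cl)cn2)CC1` gives 140 nM
Compound 3 `CNc1nc(-c2cc(N[C@H]3CC[C@H](NCCOC)CC3)ncc2Cl)cs1` gives 530 nM

Of the two actual numbers, compound 3 at 530 nM holds the higher, and its gap to compound 2 lies beyond the scatter. Compound 4 `COCCN[C@H]1CC[C@H](Nc2cc(-c3csc(NCC4CCOC4)n3)c(Cl)cn2)CC1` has oxolan-3-yl in place of hydrogen on a saturated chain carbon bound to a nitrogen on an aromatic ring. Among the compounds with values here, no measured pair isolates this change. Compound 2 differs from compound 3 in more than one place and carries a ring-bearing chain at that nitrogen. Compound 2 gives 140 nM. A lower number is therefore expected in this assay, with the estimated step of a 3.1-fold lower number from compound 3 to compound 4 (0.49 log units; beyond the scatter) likely beyond the scatter. Compound 4 is estimated at 170 nM, with an expected range from 50 nM to 550 nM.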

Compound 4, concentration for 50% growth inhibition: 493 nM
For compound 4 the middle estimate is 2.9-fold (0.46 log units) below the measured one; low and high end bracket the measured number.
By their numbers in this assay, from the lowest: compound 2; then compounds 4 and 3 (each within the scatter of the next). At a limit, above all of these: compound 1.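

In this assay, oxolan-3-yl in place of hydrogen on a saturated chain carbon bound to a nitrogen on an aromatic ring gives a 1.1-fold lower number from compound 3 to compound 4 (0.03 log units; within the scatter). Within the data shown here, this is the first reading of a single change at this position, and it shows that methylamino and ((oxolan-3-yl)methyl)amino cannot be told apart in this assay. Nothing shown gives a reason for this result.

Open, from the compounds shown here alone, is whether a group of another kind at this place, such as a carboxylic acid or a primary amine on a longer chain, would move the number beyond the scatter.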